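Variation at the aryl substituent of the piperidine-linked series

The source may hold more compounds than are shown below. What is called first, only, known or untested is meant among the compounds shown, and "the series" means these compounds.

Of the compounds shown here, three sharing one core have been measured in a functional assay on cells for agonist activity at Free fatty acid receptor 1 (Homo sapiens), read by FLIPR and calcium flux, with a stated time of 60 min; a higher number here means a larger maximal response, a lower number a smaller maximal response. Compound 1 `COc1ccc(F)c(N2CCC(COc3cccc(C(CC(=O)O)C4CC4)c3)CC2)c1` gives 114%, compound 2 `COc1ccc(C)c(N2CCC(COc3cccc(C(CC(=O)O)C4CC4)c3)CC2)c1` gives 113% and compound 3 `COc1ccc(CCC(C)(C)C)c(N2CCC(COc3cccc(C(CC(=O)O)C4CC4)c3)CC2)c1` gives 110%. The steps between them are all small: a number 1 percentage points lower from compound 1 to compound 2 (within the scatter), a number 4 percentage points lower from compound 1 to compound 3 (within the scatter) and a number 3 percentage points lower from compound 2 to compound 3 (within the scatter). Compound 3 thus sits among the other two with no separation in this assay that the scatter would not cover.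

Compound 4 `COc1ccc(CN(C)CC(C)C)c(N2CCC(COc3cccc(C(CC(=O)O)C4CC4)c3)CC2)c1` is not yet measured. It differs from compound 3 in one place: isobutyl(methyl)amino in place of neopentyl on a saturated chain carbon bound to an aromatic carbon. The step that bears most directly on this is the one into the same saturated chain carbon, a number 3 percentage points lower from compound 2 to compound 3 (within the scatter), which was within the scatter, as were a number 4 percentage points lower from compound 1 to compound 3 (within the scatter) and a number 1 percentage points lower from compound 1 to compound 2 (within the scatter). Three substituents of quite different size at this part of the core left the maximal response unchanged, so no step beyond the scatter is expected here either. The expected step is no change at the digits printed from compound 3 to compound 4 (within the scatter). Compound 4 is accordingly estimated at 110% in this assay, with a range of 95% to 125%.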

Compound 4, largest response reached (Emax), in percent of the reference or control that the assay uses: 110%
Estimate against measurement, compound 4: no gap at the digits printed; measured number inside the range.
By their numbers in this assay, from the lowest: compounds 3, 4, 2 and 1 (each within the scatter of the next).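

At this saturated chain carbon bound to an aromatic carbon, the series now includes a group carrying nitrogen: isobutyl(methyl)amino, with 1 hydrogen-bond acceptor in place of none, and this assay shows no change at the digits printed from compound 3 to compound 4 (within the scatter) for this change. The comparisons with the two smallest substituents on the shared core read a number 3 percentage points lower from compound 2 to compound 4 (within the scatter) and a number 4 percentage points lower from compound 1 to compound 4 (within the scatter), so across compounds 1 to 4, with none going against it, the maximal response does not separate a nitrogen-bearing substituent from the all-carbon or fluoro ones. No supporting measurement is available to explain this flat result.

It remains open whether a primary amine or a carboxylic acid on this chain would also stay within the scatter of these compounds. The largest response alone also leaves open whether these substituents differ in potency, which a concentration-based read-out would be needed to show.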